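From Bromo to Chloro at the Limit of Cytotoxicity

The compounds below may be only part of what the source reports. "The series", "measured", "known", "first", "only" and "open" are said of these compounds alone.

Compound 1 `O=C(c1ccccc1)c1cc(Br)ccc1OCCn1ccc(=O)[nH]c1=O` has been examined in an ADME assay on MT4 cells (Homo sapiens) for cytotoxicity, read by MTT assay, with a stated time of 4 days; on this read-out lower numbers stand for higher toxicity in this test and higher numbers for lower toxicity in this test. In this test, compound 1 gives > 301000 nM, which is a limit and not a number. Compound 2 `O=C(c1cc(Br)cc(Br)c1)c1cc(Cl)ccc1OCCn1ccc(=O)[nH]c1=O` gives > 236000 nM, which is also a limit. For the measured compounds named here, compound 1 therefore stands at a limit, as does the only other compound measured, and no exact value is available for either.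

Compound 3 `O=C(c1ccccc1)c1cc(Cl)ccc1OCCn1ccc(=O)[nH]c1=O` differs from compound 1 in one place: chloro in place of bromo on an aromatic carbon. This is chloro in place of bromo on an aromatic carbon, meta to a benzoyl group. Going by the values given here, no measured single-change step is available as a guide, so no shift beyond the scatter is expected in this assay. The estimated step that the limit leaves unreadable from compound 1 to compound 3 is accordingly small and has no firm direction. For compound 3, the expected value is 337000 nM, with an estimated range of 160000 nM to 400000 nM.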

Compound 3, half-maximal cytotoxic concentration: > 337000 nM
Compound 3 gave a limit, no number (the forecaster's own chance of this, stated with the estimate: 85%); the middle value lies on the limit itself.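

For the compounds shown here, compound 1, compound 2 and compound 3 all stand at limits in this assay, so neither the step to compound 3 from compound 1 nor the one from compound 2 can be read. The compounds shown leave open at what concentration any of them becomes cytotoxic.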